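The compounds below may be only part of what the source reports. "The series", "measured", "known", "first", "only" and "open" are said of these compounds alone.

Measured so far in a functional assay on HepG2 cells (Homo sapiens) for inhibition, read by MTT assay, with a stated time of 48 h; on this read-out higher numbers stand for weaker inhibition and lower numbers for stronger inhibition:

- Compound 1 `COc1cc(-c2nnc(SCC(=O)c3ccc4ccccc4c3)n2-c2ccc(N(C)C)cc2)cc(OC)c1OC` gives > 60000 nM, which is a limit
- Compound 2 `COc1cc(-c2nnc(SCC(=O)C3CC3)n2-c2ccc(N(C)C)cc2)cc(OC)c1OC` gives > 60000 nM, which is also a limit

Among the compounds with values here, compound 2 therefore stands at a limit of this assay and not at a number, and the only other value shown is a limit too, as the limit of > 60000 nM in this assay, at which 2 of the 2 values shown sit, records. Compound 3 `COc1cc(-c2nnc(SCC(=O)Nc3ccc(Cl)cc3)n2-c2ccc(N(C)C)cc2)cc(OC)c1OC` has not yet been measured. It differs from compound 2 by (4-chlorophenyl)amino in place of cyclopropyl on a carbonyl carbon, with (4-chlorophenyl)amino in place of cyclopropyl on a carbonyl carbon. Within the data shown here, one measured step bears on this change, since it falls on the same carbonyl carbon: a step that the two limits leave unreadable from compound 1 to compound 2. That step has no readable size, so it offers no magnitude to carry over. Among the measured compounds shown here, no step of known size can be predicted in this assay, and the expectation is that compound 3 stays near the limit, with any readable shift leaning towards stronger inhibition. For compound 3 the expected value is 45000 nM, with an estimated range from 12000 nM to 100000 nM as its bounds. This estimate amounts to an expected at least 1.3-fold lower number from compound 2 to compound 3 (0.12 log units; that floor lies within the scatter), which is a tentative figure.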

Compound 3, half-maximal inhibitory concentration: > 60000 nM
Compound 3: a limit, no number; the forecaster's own chance of this, stated with the estimate: 55%; middle value at least 1.3-fold (0.12 log units) from the limit.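

In this assay compound 3 gives > 60000 nM, which is a limit. No step among compound 1, compound 2 and compound 3 can be read, because all three stop at the same point: the limit of > 60000 nM in this assay, at which 3 of the 3 values shown sit.

The compounds shown leave open whether any group on this carbonyl carbon would give a measured number in this assay.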